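This account rests on a few compounds, and the source may have more. Where it says the series, first, only, none or still open, it means among the compounds named here.

The study measured a toxicity assay on THP-1 cells (Homo sapiens) for inhibition (a higher number here means that more compound is tolerated, a lower number that less compound is tolerated), on a small set of compounds built on a shared core. Compound 1 has the structure `COc1ccc(-c2cnc(NC(=O)c3ccccc3F)n2C)cc1`. In this assay compound 1 gives > 100000 nM, which is a limit of the assay and not a number. Two companions share the core. Compound 2, `Cn1c(-c2cccc(C#N)c2)cnc1NC(=O)c1ncc[nH]1`, gives > 50000 nM in this assay, again only a limit. Compound 3, `Cn1c(-c2ccc(F)cc2)cnc1NC(=O)c1ccc(F)cc1`, gives > 100000 nM in this assay, also a limit. So compound 1 stands where the set stands: at the limit of > 100000 nM in this assay, at which 2 of the 3 values shown sit, while compound 2 sits at the limit of > 50000 nM in this assay, at which 1 of the 3 values shown sits. Among the compounds with values here, none of the three gave a number, so no measured step between them can be read.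

The account now turns to compound 4, `COc1ccc(-c2cnc(NC(=O)c3ccccc3)n2C)cc1`, not yet measured in this assay. It differs from compound 1 in one place: hydrogen in place of fluoro on an aromatic carbon. The change is small, taking away a single fluorine on an aromatic carbon. Within the data shown here, with compounds 1, 2 and 3 all at a limit, there is no measured step from which a size could be taken; the expected step of a number no higher from compound 1 to compound 4 (the limit leaves the size open) is none beyond the scatter. Compound 4 is therefore expected to give about 100000 nM in this assay, within 50000 nM to 200000 nM, and most likely to be reported only as a limit.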

Compound 4, half-maximal cytotoxic concentration: > 100000 nM
Compound 4 was reported as a limit; the forecaster's own chance of this, stated with the estimate: 85%; the middle value lies on the limit itself.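

In this assay compound 4 gives > 100000 nM and this is a limit of the assay, not a number. Within the data shown here, compound 1 also stands only at a limit, so no step from compound 1 to compound 4 can be read. The compounds shown leave open how much of either compound is tolerated, and whether exchanging fluoro for hydrogen changes that at all.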